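Tail aryl swaps on a fixed core: microsomal half-life

The compounds below may be only part of what the source reports. "The series", "measured", "known", "first", "only" and "open" are said of these compounds alone.

Measured so far:
- compound 1, `Cc1nc(C)c([C@H](OC(C)(C)C)C(=O)O)c(N2CCC(C)(C)CC2)c1-c1ccc(OCCc2ccc(F)cc2F)cc1`: > 2 h
- compound 2, `Cc1nc(C)c([C@H](OC(C)(C)C)C(=O)O)c(N2CCC(C)(C)CC2)c1-c1ccc(OCCc2ccc(F)c(F)c2)cc1`: 0.85 h
- compound 3, `Cc1nc(C)c([C@H](OC(C)(C)C)C(=O)O)c(N2CCC(C)(C)CC2)c1-c1ccc(OCCc2cccnc2)cc1`: 0.783 h

In an ADME assay on microsomes from liver (Rattus norvegicus) for metabolic stability, read by LC-MS, tested at 0.5 uM (on this read-out lower numbers stand for a shorter-lived compound and higher numbers for a longer-lived compound), compound 1 reaches only a limit of the assay, > 2 h, so its true number is not known; this is the point described by the limit of > 2 h in this assay, at which 1 of the 3 values shown sits. Compound 2 gives 0.85 h and compound 3 gives 0.783 h in this assay. The steps are an at least 2.3-fold lower number from compound 1 to compound 2 (0.37 log units; beyond the scatter) and an at least 2.5-fold lower number from compound 1 to compound 3 (0.40 log units; beyond the scatter), while a 1.1-fold lower number from compound 2 to compound 3 (0.04 log units; within the scatter).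

Compound 4, `Cc1nc(C)c(CCOc2ccc(-c3c(C)nc(C)c([C@H](OC(C)(C)C)C(=O)O)c3N3CCC(C)(C)CC3)cc2)s1`, is not yet measured. Relative to compound 1 the change is 2,4-dimethyl-1,3-thiazol-5-yl in place of 2,4-difluorophenyl on a saturated chain carbon, two bonds along the chain from an oxygen on an aromatic ring. The two measured steps that bear on it both replace the same 2,4-difluorophenyl group at the same place, and both give a lower number that is at least modest. Compound 4 is therefore expected to land below the limit seen for compound 1, with an estimated step of an at least 2.5-fold lower number from compound 1 to compound 4 (0.39 log units; beyond the scatter) in this assay. The estimate for compound 4 in this assay is 0.8 h, with a range from 0.35 h to 2 h.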

Compound 4, half-life: > 2 h
Compound 4 was reported as a limit; the forecaster's own chance of this, stated with the estimate: 20%; at least 2.5-fold (0.39 log units) between middle value and limit.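

In this assay compound 4 gives > 2 h, which is a limit of the assay. The lower numbers of compound 2 and compound 3 had suggested that leaving 2,4-difluorophenyl at this place, on a saturated chain carbon, two bonds along the chain from an oxygen on an aromatic ring, costs half-life, but 2,4-dimethyl-1,3-thiazol-5-yl goes against that pattern, with an at least 2.5-fold higher number from compound 3 to compound 4 (0.40 log units; beyond the scatter) and an at least 2.3-fold higher number from compound 2 to compound 4 (0.37 log units; beyond the scatter), so the longer half-life is not unique to 2,4-difluorophenyl. The step between compound 1 and compound 4 cannot be read because both compounds sit at the limit: the limit of > 2 h in this assay, at which 2 of the 4 values shown sit.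

On these data alone, how far compound 1 and compound 4 lie past that limit stays open, and with it any order between 2,4-difluorophenyl and 2,4-dimethyl-1,3-thiazol-5-yl. Also open, as far as these compounds go, is what the two methyl groups contribute, which an unsubstituted 1,3-thiazol-5-yl or a 2,4-dimethylphenyl at the same place would help to separate from the contribution of the ring itself.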